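This account rests on a few compounds, and the source may have more. Where it says the series, first, only, none or still open, it means among the compounds named here.

Measured so far:
compound 1, `COc1cc2c(Oc3ccc(NC(=O)c4nn(-c5ccccc5C(F)(F)F)c(=O)cc4C)cc3F)ccnc2cc1OCCCN1CCN(C)CC1`, 1170 nM
compound 2, `COc1cc2c(Oc3ccc(NC(=O)c4nn(-c5cccc(F)c5)c(=O)cc4C)cc3F)ccnc2cc1OCCCN1CCCCC1`, 1500 nM

Both numbers come from a functional assay on U-87MG ATCC cells (Homo sapiens) for inhibition, read by MTT assay, with a stated time of 72 h; a lower number here means a stronger inhibitor, a higher number a weaker inhibitor. Compound 2 stands alongside compound 1: the gap between its number and that of compound 1 lies within the usual scatter, so the two compounds are not separated by this read-out. They differ from each other in two places, so no single step can be read off between them.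

Compound 3, `COc1cc2c(Oc3ccc(NC(=O)c4nn(-c5cccc(F)c5)c(=O)cc4C)cc3F)ccnc2cc1OCCCN1CCN(C)CC1`, has not yet been measured in this assay. It differs from compound 2 in one place only: 4-methylpiperazin-1-yl in place of piperidin-1-yl on a saturated chain carbon, three bonds along the chain from an oxygen on an aromatic ring. The group that enters is the same one carried by compound 1.

Within the data shown here, no measured pair shows this change on its own. Because compound 1 with the same entering group gives 1170 nM, and compound 2 with the leaving group gives 1500 nM, no shift beyond the scatter is expected. Compound 3 is estimated at 1300 nM, with a range from 600 nM to 2800 nM. The step this implies, a 1.2-fold lower number from compound 2 to compound 3 (0.06 log units; within the scatter), is expected to be small and within the scatter.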

Compound 3, half-maximal inhibitory concentration: 1590 nM
Beside the measured number, compound 3's estimate is 1.2-fold (0.09 log units) below it; the measured number falls inside the stated range.
By their numbers in this assay, from the lowest: compounds 1, 2 and 3 (each within the scatter of the next).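

In this assay the change from piperidin-1-yl to 4-methylpiperazin-1-yl on a saturated chain carbon, three bonds along the chain from an oxygen on an aromatic ring, can now be read on its own, and it gives a 1.1-fold higher number from compound 2 to compound 3 (0.03 log units; within the scatter) with the 3-fluorophenyl group held constant. The result also isolates a second place, where 3-fluorophenyl in place of 2-(trifluoromethyl)phenyl on an aromatic nitrogen gives a 1.4-fold higher number from compound 1 to compound 3 (0.13 log units; within the scatter) with the 3-(4-methylpiperazin-1-yl)propyl chain held constant. Neither single change separates its two compounds in this read-out, and nothing further is available that could bear on these results.

The compounds shown leave open whether a morpholin-4-yl group in place of these two rings, or a shorter chain carrying the same rings, would move the number beyond the scatter. They also leave open whether the same picture would hold with an unsubstituted phenyl or a 4-chlorophenyl group on the aromatic nitrogen.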